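Biaryl urea series: five-membered heteroaryl swap on the benzyl arm

The source may report more compounds than this note shows. Statements on the series, on what has been measured and on what is new or still open speak of the compounds shown alone.

Measured compounds:
compound 1 `Cc1cc(C)c(NC(=O)N(Cc2ccc(-c3cccs3)cc2)C2CCCCCC2)c(C)c1`, 22 nM
compound 2 `Cc1cc(C)c(NC(=O)N(Cc2ccc(-c3cccnc3)cc2)C2CCCCCC2)c(C)c1`, 130 nM
compound 3 `Cc1cc(C)c(NC(=O)N(Cc2ccc(-c3cnn(C)c3)cc2)C2CCCCCC2)c(C)c1`, 47 nM

In an assay on microsomes from intestine for inhibition of acyl-CoA:cholesterol acyltransferase (Oryctolagus cuniculus) (on this read-out lower numbers stand for stronger inhibition and higher numbers for weaker inhibition), compound 3 gives 47 nM, the second highest of the three numbers: compound 1 sits nearest, compound 2 furthest. Within the three, a 2.1-fold higher number from compound 1 to compound 3 (0.33 log units; beyond the scatter) and a 2.8-fold lower number from compound 2 to compound 3 (0.44 log units; beyond the scatter); the larger move is a 5.9-fold higher number from compound 1 to compound 2 (0.77 log units; beyond the scatter).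

Compound 4 `Cc1cc(C)c(NC(=O)N(Cc2ccc(-n3ccnc3)cc2)C2CCCCCC2)c(C)c1` is not yet measured. It differs from compound 3 only in one spot: 1H-imidazol-1-yl in place of 1-methyl-1H-pyrazol-4-yl on an aromatic carbon. The bearing steps are the three heteroaryl exchanges above, all of them modest; the two that replace or introduce a five-membered aromatic ring with 2 hetero atoms, a 2.1-fold higher number from compound 1 to compound 3 (0.33 log units; beyond the scatter) and a 2.8-fold lower number from compound 2 to compound 3 (0.44 log units; beyond the scatter), are the closest parallels. Since every swap so far has moved this assay by a modest amount and compound 1 stands lowest, the expected outcome for compound 4 is a small to modest step, more likely toward a higher number than a lower one, though a step within the scatter is also plausible. The expected step is a 1.7-fold higher number from compound 3 to compound 4 (0.23 log units; within the scatter). The estimate for compound 4 in this assay is 80 nM, with a range from 30 nM to 250 nM.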

Compound 4, half-maximal inhibitory concentration: 47 nM
Estimate against measurement, compound 4: 1.7-fold (0.23 log units) above; the measured number falls inside the stated range.
By their numbers in this assay, from the lowest: compound 1; then compounds 3 and 4 (each within the scatter of the next); then compound 2.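

In this assay, replacing 1-methyl-1H-pyrazol-4-yl (6 heavy atoms) with 1H-imidazol-1-yl (5 heavy atoms) gives no change at the digits printed from compound 3 to compound 4 (within the scatter), so at this place, para to a large group, the read-out does not separate these two five-membered aromatic rings with 2 hetero atoms. The remaining steps match those of compound 3, with a 2.8-fold lower number from compound 2 to compound 4 (0.44 log units; beyond the scatter) and a 2.1-fold higher number from compound 1 to compound 4 (0.33 log units; beyond the scatter), which places both of these rings in the interval left by the thiophen-2-yl and pyridin-3-yl groups; ring size alone does not sort the series, as compound 1 also carries a five-membered ring yet stands apart from compound 3 and compound 4. No supporting data bear on why the two groups read alike in this assay.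

The compounds shown leave open whether the tolerance extends to a five-membered ring with three or more ring nitrogens, such as 1,2,4-triazol-1-yl, or to a non-aromatic group such as morpholin-4-yl. As far as these compounds go, it also remains open how a charged substituent on the ring, such as a carboxylic acid or a dimethylaminomethyl group, would read here.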